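The source may hold more compounds than are shown below. What is called first, only, known or untested is meant among the compounds shown, and "the series" means these compounds.

Of the compounds shown here, two have been measured. Compound 1 `O=C(/C=C/c1ccc(Br)cc1)Nc1cc2c(Nc3ccc(F)c(Cl)c3)ncnc2cc1O[C@H]1CCOC1` gives 35300 nM in a functional assay on A549 cells (Homo sapiens) for cytotoxicity, read by MTT assay, with a stated time of 72 h (a lower number here means a stronger inhibitor, a higher number a weaker inhibitor), while compound 2 `O=C(/C=C/c1ccc(F)cc1Cl)Nc1cc2c(Nc3ccc(F)c(Cl)c3)ncnc2cc1O[C@H]1CCOC1` gives 5190 nM in this assay. For the measured compounds named here, the only step so far, a 6.8-fold lower number from compound 1 to compound 2 (0.83 log units; beyond the scatter), leaves compound 2 with the lower of the two numbers, and the gap between compounds 1 and 2 lies beyond the scatter.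

Compound 3 `N#Cc1ccc(/C=C/C(=O)Nc2cc3c(Nc4ccc(F)c(Cl)c4)ncnc3cc2O[C@H]2CCOC2)cc1` differs from compound 2 by a change at the same place: 4-cyanophenyl in place of 2-chloro-4-fluorophenyl on a double-bonded chain carbon bound to a double-bonded chain carbon. Going by the values given here, no measured step covers this exact exchange. The step from compound 1 to compound 2 shows that changing the aryl group on the chain carbon can move the number by a modest amount, so a change there in compound 3 is expected to matter. Because compound 1, which also carries a single substituent on that phenyl ring, gives 35300 nM, compound 3 is expected to give a higher number than compound 2, a step of a 2.9-fold higher number from compound 2 to compound 3 (0.46 log units; beyond the scatter). Compound 3 is therefore estimated at 15000 nM, within 4000 nM to 50000 nM.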

Compound 3, half-maximal inhibitory concentration: "not active" (no number reported)
Compound 3: no number reported, and the estimate cannot be compared.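

In this assay, for the compounds shown here, compound 3 is reported as not active, without a number, so no step from compound 2 to compound 3 can be read. Nothing shown bears on this result. The compounds shown leave open how compound 3 truly ranks against compound 1 and compound 2.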